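The source may report more compounds than this note shows. Statements on the series, on what has been measured and on what is new or still open speak of the compounds shown alone.

In a physicochemical assay for metabolic stability, read by HPLC, at pH 4.5, tested at 10 uM (a higher number here means that the compound lasts longer, a lower number that the compound disappears faster), compound 1 `O=C(NCCCCc1ccccc1)n1nnc2ncccc21` gives > 2 h, which is a limit of the assay and not a number. Two compounds with a shared core give actual numbers. Compound 2 `Cc1ccccc1CNC(=O)n1cnc2ccccc21` gives 1.37 h, and compound 3 `Cc1ccccc1CNC(=O)n1c(N)nc2ccccc21` gives 0.45 h. Compound 3 therefore holds the lower of these two numbers. Among the measured compounds shown here, the only measured step between compounds, amino in place of hydrogen on an aromatic carbon, is a 3.0-fold lower number from compound 2 to compound 3 (0.48 log units; beyond the scatter).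

The next structure is compound 4 `Nc1nc2ccccc2n1C(=O)NCc1ccccc1`, and the change is hydrogen in place of methyl on an aromatic carbon. This places hydrogen where methyl stood on an aromatic carbon, turning 2-methylphenyl into phenyl. The amino group stays in place, so the measured step does not touch the group that changes here. It shows only that a single small replacement can move the half-life beyond the scatter. For the measured compounds named here, no measured pair shows what removing this methyl does, so neither direction can be favoured. The closest anchor is compound 3 at 0.45 h.

The expected change is a 1.1-fold higher number from compound 3 to compound 4 (0.05 log units; within the scatter), which means no shift beyond the scatter. Compound 4 is estimated at 0.5 h, with an expected range from 0.2 h to 1.1 h.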

Compound 4, half-life: 0.7 h
Compound 4: middle estimate off by 1.4-fold (0.15 log units), on the low side, within the range that was stated.
By their numbers in this assay, from the lowest: compounds 3, 4 and 2 (each within the scatter of the next, the first and the last beyond it). At a limit, above all of these: compound 1.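

In this assay, the change from 2-methylphenyl to phenyl, made with the amino group kept in place, gives a 1.6-fold higher number from compound 3 to compound 4 (0.19 log units; within the scatter). Among the compounds shown here, this is the first measured look at this position, an aromatic carbon ortho to a large group, and it shows that replacing the methyl with hydrogen leaves the half-life within the usual scatter of repeated measurements, so this single pair gives no sign that the methyl matters for the read-out. For the compounds shown here, the only earlier step, made at a different place on the molecule, was a 3.0-fold lower number from compound 2 to compound 3 (0.48 log units; beyond the scatter), so a small replacement can move this number beyond the scatter at one place and not at another, and nothing given here bears on why the two places differ.

The compounds shown leave open whether a larger or different group at this position, such as a chlorine atom or a methoxy group, would give a half-life beyond the scatter. They also leave open whether the same swap of methyl for hydrogen would read the same way on the shared core without the amino group.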